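Extending the urea of compound 1 toward compound 3

The source may hold more compounds than are shown below. What is called first, only, known or untested is meant among the compounds shown, and "the series" means these compounds.

Compound 1 `COc1cc(NC(C)CCCNC(=O)Nc2cccc(F)c2)c2ncccc2c1` gives 23000 nM in a functional assay on MOLT-4 cells (Homo sapiens) for inhibition, read by MTT assay, with a stated time of 72 h; on this read-out lower numbers stand for stronger inhibition and higher numbers for weaker inhibition.
Compound 2 `COc1cc(NC(C)CCCNC(=O)Nc2ccc(F)cc2)c2ncccc2c1` gives 24000 nM in this assay.

Compound 1 holds the lowest of these two numbers, and compound 2 sits within the scatter of it: a 1.0-fold higher number from compound 1 to compound 2 (0.02 log units; within the scatter). Compound 3 `COc1cc(NC(C)CCCNC(=O)NNC(=O)Nc2cccc(Cl)c2)c2ncccc2c1` differs from compound 1 in one place: ((3-chlorophenyl)carbamoyl)amino in place of 3-fluorophenyl on an amide-type nitrogen. Among the measured compounds shown here, the only measured step exchanges 4-fluorophenyl for 3-fluorophenyl and so does not bear on this larger change; it gives no direction. Without a guide, compound 3 is expected to give 25000 nM, between 8000 nM and 80000 nM. That estimate means a 1.1-fold higher number from compound 1 to compound 3 (0.04 log units; within the scatter) is expected.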

Compound 3, half-maximal inhibitory concentration: 93000 nM
The estimate for compound 3 lay 3.7-fold (0.57 log units) below the measured number; measured number above the stated range.
By their numbers in this assay, from the lowest: compounds 1 and 2 (each within the scatter of the next); then compound 3.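

Placing ((3-chlorophenyl)carbamoyl)amino on this amide-type nitrogen gives a 4.0-fold higher number from compound 1 to compound 3 (0.61 log units; beyond the scatter) in this assay and likewise a 3.9-fold higher number from compound 2 to compound 3 (0.59 log units; beyond the scatter). So this position, where the two fluorophenyl compounds could not be told apart, does respond to a larger change, although modestly and toward weaker inhibition. Nothing available explains this rise.

The entering group differs in both its longer link and its chlorine, so the compounds shown leave open which of the two matters. Going by these compounds, how a simple amine or a carboxylic acid would read at this nitrogen also stays open.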